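Working notes: a large group gives way to methyl

The source may report more compounds than this note shows. Statements on the series, on what has been measured and on what is new or still open speak of the compounds shown alone.

In a functional assay on HepG2 cells (Homo sapiens) for cytotoxicity, read by sulforhodamine B assay, with a stated time of 24 h (a higher number here means a weaker inhibitor, a lower number a stronger inhibitor), compound 2 `N=c1oc2ccccc2cc1C(=O)N/N=C1\C(=O)Nc2ccc(S(=O)(=O)N3CCOCC3)cc21` gives 7820 nM and compound 1 `N#CCC(=O)N/N=C1\C(=O)Nc2ccc(S(=O)(=O)N3CCOCC3)cc21` gives 7530 nM, which places the two within the scatter of each other. Compound 3 `CC(=O)N/N=C1\C(=O)Nc2ccc(S(=O)(=O)N3CCOCC3)cc21` differs from compound 2 by one carbon atom in place of a group of 11 heavy atoms (9 carbon, 1 nitrogen, 1 oxygen; one six-membered aromatic ring of carbon only, one six-membered aromatic ring with 1 hetero atom), on a carbonyl carbon, the entering group being methyl. For the measured compounds named here, the one measured step at that carbonyl carbon, a 1.0-fold higher number from compound 1 to compound 2 (0.02 log units; within the scatter), lies within the scatter, although a single pair is thin evidence. No change beyond the scatter is therefore expected in this assay, and the estimated move is a 1.0-fold higher number from compound 2 to compound 3 (0.01 log units; within the scatter). The expected value for compound 3 is 8000 nM, with an estimated range of 3500 nM to 18000 nM.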

Compound 3, half-maximal inhibitory concentration: 27500 nM
For compound 3 the middle estimate is 3.4-fold (0.54 log units) below the measured one; the whole stated range lies below it.
By their numbers in this assay, from the lowest: compounds 1 and 2 (each within the scatter of the next); then compound 3.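

At the carbonyl carbon, this assay does respond to the group: methyl in place of the group of 11 heavy atoms gives a 3.5-fold higher number from compound 2 to compound 3 (0.55 log units; beyond the scatter) and hydrogen in place of cyano on the saturated chain carbon gives a 3.7-fold higher number from compound 1 to compound 3 (0.56 log units; beyond the scatter) so both larger groups part from methyl beyond the scatter. The cyano alone is thus enough to separate compound 1 from compound 3, although compound 1 and compound 2 differ widely in heavy-atom count. Nothing shown bears on the cause of this difference.

Open, going by these compounds, is whether an ethyl group, a longer chain or an amine on the carbonyl carbon would fall with compound 1 and compound 2 or with compound 3.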